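Pyrazolone hydrazides: swapping the aryl group on compound 2

The source may report more compounds than this note shows. Statements on the series, on what has been measured and on what is new or still open speak of the compounds shown alone.

Measured so far:
compound 1 `COc1ccccc1-c1cc(=O)[nH]n1-c1ccc(C(=O)NNC(=O)CO[N+](=O)[O-])cc1` — 55.7%
compound 2 `CCOC(=O)c1c(-c2ccc([N+](=O)[O-])cc2)n(-c2ccc(C(=O)NNC(=O)CO[N+](=O)[O-])cc2)[nH]c1=O` — 28.1%

In a functional assay on the whole organism (strain Wistar) for inhibition, with Rattus norvegicus as the target, read by paw edema, with stated times of 2 h and 1 h, at a dose of 6 mg/kg by the oral route (a lower number here means less inhibition, a higher number more inhibition at the dose given (going by the name of the read-out)), compound 1 gives 55.7%, while compound 2 gives 28.1%. Compound 2 thus stands lowest of the two numbers, and the gap to compound 1 lies beyond the scatter. The two compounds differ in more than one place, so no single step can be read from them.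

Compound 3 `CCOC(=O)c1c(-c2ccccc2OC)n(-c2ccc(C(=O)NNC(=O)CO[N+](=O)[O-])cc2)[nH]c1=O` keeps the core of compound 2, with its ethoxycarbonyl group, and changes only the aryl group: 2-methoxyphenyl in place of 4-nitrophenyl on an aromatic carbon. The same 2-methoxyphenyl sits on the core of compound 1.

Compound 1 with 55.7% suggests the entering group is compatible with higher inhibition, so compound 3 is expected to rise, giving an expected step of a number 11.9 percentage points higher from compound 2 to compound 3 (beyond the scatter). Compound 3 is therefore estimated at 40%, in the range 25% to 58%.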

Compound 3, a percentage reported as inhibition, in the whole organism at one dose (the size of the read-out at that dose, not a potency): 30.7%
For compound 3 the middle estimate is 9.3 percentage points above the measured one; the range from low to high includes it.
By their numbers in this assay, from the lowest: compounds 2 and 3 (each within the scatter of the next); then compound 1.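

In this assay the exchange of 4-nitrophenyl for 2-methoxyphenyl gives a number 2.6 percentage points higher from compound 2 to compound 3 (within the scatter) and so, with the ethoxycarbonyl group present, does not separate these two compounds. Ethoxycarbonyl in place of hydrogen on an aromatic carbon of the core of compound 1 gives a number 25 percentage points lower from compound 1 to compound 3 (beyond the scatter) and is the single-place change in this series that lies beyond the scatter, so the gap seen earlier between compound 1 and compound 2 now finds a counterpart at this site rather than at the aryl group. No supporting data bear on why either step has its size.

The compounds shown leave open whether the aryl exchange would also leave the read-out unresolved on the core without the ethoxycarbonyl group. They also leave open how a carboxylic acid or a primary amide at the ethoxycarbonyl site, or a longer ester chain there, would compare.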